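Adding a Methyl to the Ketone Side Chain

A few compounds are considered here, and "the series" means these few. Any claim that something is new, unique, unknown or untested is made for them only; others in the source may bear on it.

Of the compounds shown here, three have been measured in an assay on HEK293 cells for positive allosteric modulation of metabotropic glutamate receptor 2 (Rattus norvegicus), read by thallium flux, with a stated time of 2.5 min; on this read-out lower numbers stand for an effect already at smaller amounts and higher numbers for an effect only at larger amounts of compound. Compound 1 `COc1cc(C(=O)O)ccc1OCCCCOc1ccc(C(=O)CC(C)C)c(O)c1C` gives 40 nM. Compound 3 `CCC(=O)c1ccc(OCCCCOc2cccc(C(=O)O)c2C)c(C)c1O` gives 62 nM, and compound 2 `Cc1c(OCCCCOc2ccc(C(=O)C(C)C)c(O)c2C)cccc1C(=O)O` gives 149 nM. Compounds 3 and 2 differ in one place: methyl in place of hydrogen on a saturated chain carbon bound to a carbonyl carbon and a saturated chain carbon. That change made a step of a 2.4-fold higher number from compound 3 to compound 2 (0.38 log units; beyond the scatter) in this assay.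

Compound 4 `COc1cc(C(=O)O)ccc1OCCCCOc1ccc(C(=O)CC(C)(C)C)c(O)c1C` is not yet measured. It differs from compound 1 in one place: methyl in place of hydrogen on a saturated chain carbon bound to three saturated chain carbons. The difference between the core of compound 1 and the core of compound 3 is not broken down here. Going by the values given here, the change from compound 1 to compound 4 is the same kind of change as the one from compound 3 to compound 2, but not the same: in the first case the methyl enters on a saturated chain carbon bound to a carbonyl carbon and a saturated chain carbon, in the second on a saturated chain carbon bound to three saturated chain carbons.

Resting on the step of a 2.4-fold higher number from compound 3 to compound 2 (0.38 log units; beyond the scatter), compound 4 is expected to give about 80 nM in this assay, a step of a 2.0-fold higher number from compound 1 to compound 4 (0.30 log units; within the scatter), with a likely range from 35 nM to 200 nM.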

Compound 4, half-maximal effective concentration: 47 nM
For compound 4 the middle estimate is 1.7-fold (0.23 log units) above the measured one; low and high end bracket the measured number.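

In this assay, turning the isobutyl group of compound 1 into the neopentyl group of compound 4 gives a 1.2-fold higher number from compound 1 to compound 4 (0.07 log units; within the scatter), so this extra methyl leaves no change that can be told from the scatter. The earlier methyl step looks larger, yet the two steps cannot be told apart: the same change on two cores in this assay, a 2.4-fold higher number (0.38 log units; beyond the scatter) from compound 3 to compound 2 and a 1.2-fold higher number (0.07 log units; within the scatter) from compound 1 to compound 4, 2.0-fold (0.31 log units) apart, within the scatter of two such steps. Going by these compounds alone, this shows that the data do not contradict a similar effect on both cores, but it does not show that the change carries over unaltered: there are only two steps, and the methyl enters on a saturated chain carbon bound to a carbonyl carbon in one and on a saturated chain carbon bound to three saturated chain carbons in the other.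

No ketone side chain shown here appears on both cores, so the contribution of the core alone stays open. Also open, on these data alone, is how the numbers would respond to a larger group on the ketone side chain, such as cyclohexyl, or to an amine there.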